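The compounds below may be only part of what the source reports. "The series", "measured", "known", "first", "only" and "open" are said of these compounds alone.

Compound 1 `Cc1cccc(/C=N/Nc2ncc3c(n2)n(C2CCCC2)c(=O)c(=O)n3C)c1` carries a 3-methylphenyl on a carbon with a double bond to nitrogen. In a functional assay on HCT-116 cells (Homo sapiens) for antiproliferative activity, read by MTT assay (on this read-out higher numbers stand for weaker inhibition and lower numbers for stronger inhibition), compound 1 gives only a limit, > 100000 nM, and no number; it is the compound that sits at the limit of > 100000 nM in this assay, at which 1 of the 3 values shown sits. Compound 2 `Cn1c(=O)c(=O)n(C2CCCC2)c2nc(N/N=C/c3ccc(F)c(Cl)c3)ncc21` gives 9020 nM in this assay, and compound 3 `Cn1c(=O)c(=O)n(C2CCCC2)c2nc(N/N=C/c3ccco3)ncc21` gives 78700 nM. Among the measured steps, an at least 11-fold lower number from compound 1 to compound 2 (1.04 log units; beyond the scatter) is the only one that clearly lowers the number, whereas an at least 1.2-fold lower number from compound 1 to compound 3 (0.10 log units; that floor lies within the scatter) and, going the other way, an 8.7-fold higher number from compound 2 to compound 3 (0.94 log units; beyond the scatter).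

Compound 4 `Cc1cc(C)c(/C=N/Nc2ncc3c(n2)n(C2CCCC2)c(=O)c(=O)n3C)c(C)c1` differs from compound 1 by 2,4,6-trimethylphenyl in place of 3-methylphenyl on a carbon with a double bond to nitrogen. Among the compounds with values here, none of the measured steps puts a more heavily methylated phenyl in this place; the only clear gain came from the 3-chloro-4-fluorophenyl of compound 2. Compound 1 stands at the limit, so the step to compound 4 is expected to be a step that the limit leaves unreadable from compound 1 to compound 4, with no movement beyond the scatter. Compound 4 is therefore expected to give about 150000 nM, with a range from 50000 nM to 500000 nM, and most probably again only a limit.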

Compound 4, half-maximal inhibitory concentration: 7920 nM
Compound 4: middle estimate off by 19-fold (1.28 log units), on the high side, outside the stated range (below it).
By their numbers in this assay, from the lowest: compounds 4 and 2 (each within the scatter of the next); then compound 3. At a limit, above all of these: compound 1.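

In this assay, this position turns out not to depend on halogens for a lower number: the 2,4,6-trimethylphenyl, which carries only methyl groups, gives an at least 12-fold lower number from compound 1 to compound 4 (1.10 log units; beyond the scatter). The same group gives a 9.9-fold lower number from compound 3 to compound 4 (1.00 log units; beyond the scatter), whereas the comparison with the halogen-bearing phenyl gives a 1.1-fold lower number from compound 2 to compound 4 (0.06 log units; within the scatter), so compound 2 and compound 4 cannot be told apart in this assay. Compound 1 gives only a limit, so the first of these steps is a floor and its true size stays unknown: the limit of > 100000 nM in this assay, at which 1 of the 4 values shown sits.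

The compounds shown do not tell which of the methyl groups of compound 4 accounts for the change, nor why it arises. They also leave open whether an amine or a carboxylic acid on the phenyl in this place would keep the number as low.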